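Compound 3 to compound 4: a pyrrolidine swap at the limit

The source may hold more compounds than are shown below. What is called first, only, known or untested is meant among the compounds shown, and "the series" means these compounds.

In an ADME assay on microsomes from liver (Homo sapiens) for metabolic stability, read by LC-MS, with NADPH named in the record, with a stated time of 60 min, tested at 1 uM, in the absence of a further agent (a lower number here means that less of the compound is left, a higher number that more of the compound is left), compound 3 (`COc1ccc(-c2c(C)nc3c(N4CC[C@H](O)C4)cc(C)nn23)cc1OC`) gives > 95%, which is a limit of the assay and not a number. Compound 1 (`COc1ccc(-c2c(C)nc3c(N4CC[C@@H](NC(=O)COc5ccccc5)C4)cc(C)nn23)cc1OC`) gives > 95%, also a limit. Compound 2 (`COc1ccc(-c2c(C)nc3c(N4CC[C@@H](NS(=O)(=O)c5ccc(Cl)cc5)C4)cc(C)nn23)cc1OC`) gives > 95%, again a limit. Going by the values given here, the whole series so far is summed up as the limit of > 95% in this assay, at which 3 of the 3 values shown sit.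

Compound 4 (`COc1ccc(-c2c(C)nc3c(N4CC[C@@H](SC(C)=O)C4)cc(C)nn23)cc1OC`) has 3-(acetylsulfanyl)pyrrolidin-1-yl in place of 3-hydroxypyrrolidin-1-yl on an aromatic carbon of a six-membered aromatic ring with 2 nitrogen. The counted difference is 3-(acetylsulfanyl)pyrrolidin-1-yl in place of 3-hydroxypyrrolidin-1-yl on an aromatic carbon.

Among the compounds with values here, the only measured step is a step that the two limits leave unreadable from compound 1 to compound 2. Within the data shown here, it has no size to carry over, and no measured compound contains the entering group. The data therefore give no measured guide to the size of this change in this assay. With all three values at the limit, the working expectation is no step beyond the scatter. Any step that does appear is expected to be downward, toward less of the compound left, and the range is kept wide on that side.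

The estimated step is a number at least 7 percentage points lower from compound 3 to compound 4 (that floor lies within the scatter). For compound 4 the expected value is 88%, with an estimated range from 55% to 100%.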

Compound 4, percent of the compound remaining: > 95%
Compound 4 was reported as a limit (the forecaster's own chance of this, stated with the estimate: 50%); middle value at least 7 percentage points away from the limit.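

In this assay compound 4 gives > 95%, a limit of the assay and not a number. Its steps from compound 1, compound 2 and compound 3 therefore join limit to limit, and none of them can be read. The compounds shown leave open whether these pyrrolidine substituents differ at all in the percent of compound remaining, with every value resting on the same limit: the limit of > 95% in this assay, at which 4 of the 4 values shown sit.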